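The source may report more compounds than this note shows. Statements on the series, on what has been measured and on what is new or still open speak of the compounds shown alone.

In an ADME assay on RAW264.7 cells (Mus musculus) for cytotoxicity, read by MTT assay (on this read-out lower numbers stand for stronger inhibition and higher numbers for weaker inhibition), compound 3 `CCCCCCCCCCOc1cccc(O)c1C(=O)/C=C/c1cc(OC)c(O)c(OC)c1` gives > 30000 nM, which is a limit and not a number. Compound 1 `CCCCC/C=C\CCCCOc1cccc(O)c1C(=O)/C=C/c1ccc(O)cc1` also gives only a limit, > 30000 nM. Compound 2 `O=C(/C=C/c1ccc(O)cc1)c1c(O)cccc1OCC1CCCCC1` likewise gives only a limit, > 30000 nM. Going by the values given here, all the compounds measured so far therefore sit at the same limit, as the limit of > 30000 nM in this assay, at which 3 of the 3 values shown sit, shows.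

Compound 4 `CCCCCCCCCCOc1cccc(O)c1C(=O)/C=C/c1ccc(C)cc1` differs from compound 3 in one place: 4-methylphenyl in place of 4-hydroxy-3,5-dimethoxyphenyl on a double-bonded chain carbon bound to a double-bonded chain carbon. Among the compounds with values here, the only measured step, a step that the two limits leave unreadable from compound 1 to compound 2, concerns a different part of the molecule, and its size cannot be read, so it offers no size to carry over. Within the data shown here, no measured step touches the 4-hydroxy-3,5-dimethoxyphenyl group.

The expectation therefore rests on compound 3 and its limit of > 30000 nM. The expected step of a number no higher from compound 3 to compound 4 (the limit leaves the size open) is none beyond the scatter, and no direction can be predicted. Compound 4 is estimated at 30000 nM, with an expected range from 12000 nM to 60000 nM.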

Compound 4, half-maximal inhibitory concentration: > 30000 nM
Compound 4 gave a limit, no number; the forecaster's own chance of this, stated with the estimate: 70%; the middle value lies on the limit itself.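

In this assay, going by these compounds alone, compound 3 and compound 4 both give only a limit, not a number, so no step between them can be read. The compounds shown leave open what any of their actual values are and whether any change among them alters the value at all: the limit of > 30000 nM in this assay, at which 4 of the 4 values shown sit.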